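A few compounds are considered here, and "the series" means these few. Any claim that something is new, unique, unknown or untested is made for them only; others in the source may bear on it.

The measured compounds in a functional assay on A2780 cells (Homo sapiens) for antiproliferative activity, read by sulforhodamine B assay, with a stated time of 48 h; on this read-out higher numbers stand for weaker inhibition of growth and lower numbers for stronger inhibition of growth:

Compound 1, `Cc1ccc(S(=O)(=O)N2CCC(Br)CC2)cc1`, gives > 100000 nM, a limit of the assay.
Compound 2, `Cc1ccc(S(=O)(=O)N2CC[C@@H](Br)C[C@@H]2CC(C)C)cc1`, gives 39000 nM.
Compound 3, `Cc1ccc(S(=O)(=O)N2CC[C@@H](Br)C[C@@H]2C2CCCCC2)cc1`, gives > 100000 nM, again a limit of the assay.

Compound 3 thus stands at the weak end of this small set; its number is one of the two values that sit at the limit of > 100000 nM in this assay, at which 2 of the 3 values shown sit. Compound 4, `Cc1ccc(S(=O)(=O)N2CC[C@@H](Br)C[C@@H]2c2ccccc2)cc1`, differs from compound 3 by phenyl in place of cyclohexyl on a saturated ring carbon. Of the measured steps, an at least 2.5-fold higher number from compound 2 to compound 3 (0.40 log units; beyond the scatter) touches the same ring carbon, while a step that the two limits leave unreadable from compound 1 to compound 3 gives no readable size. Going by the values given here, no measured step swaps cyclohexyl for phenyl, so the direction is open. Compound 4 is therefore estimated at 80000 nM, between 25000 nM and 250000 nM. For compound 4 the expected step is an at least 1.2-fold lower number from compound 3 to compound 4 (0.09 log units; that floor lies within the scatter).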

Compound 4, concentration for 50% growth inhibition: > 100000 nM
Compound 4: a limit, no number; the forecaster's own chance of this, stated with the estimate: 55%; middle value at least 1.2-fold (0.09 log units) from the limit.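

In this assay compound 4 gives > 100000 nM, a limit of the assay and not a number. Phenyl in place of isobutyl gives an at least 2.5-fold higher number from compound 2 to compound 4 (0.40 log units; beyond the scatter), so on this saturated ring carbon the aromatic and the non-aromatic six-membered ring both end at the limit, and only isobutyl gives a number. The steps to compound 4 from compound 1 and compound 3 cannot be read, and the limit now holds most of the set: the limit of > 100000 nM in this assay, at which 3 of the 4 values shown sit.

As far as these compounds go, whether a longer chain or an amine on this carbon would go beyond isobutyl stays open. From the compounds shown here alone, how far compound 1, compound 3 and compound 4 differ also stays open.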